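Two Inactive Amides and a Chloro-Branched Third

The source may report more compounds than this note shows. Statements on the series, on what has been measured and on what is new or still open speak of the compounds shown alone.

Compound 1 `C/C=C/C(=O)Nc1cccc(-c2nc3ccccc3s2)c1`: > 25000 nM
Compound 2 `CN(C)CCC(=O)Nc1cccc(-c2nc3ccccc3s2)c1`: > 25000 nM

In an ADME assay on HEK293 cells (Homo sapiens) for inhibition, with a stated time of 72 h (on this read-out higher numbers stand for an effect only at larger amounts of compound and lower numbers for an effect already at smaller amounts), compound 1 gives only a limit, > 25000 nM. In this assay compound 2 likewise gives only a limit, > 25000 nM. Going by the values given here, the single measured step, a step that the two limits leave unreadable from compound 1 to compound 2, therefore has no readable size. Compound 2 thus stands at the limit of > 25000 nM in this assay, at which 2 of the 2 values shown sit, and the numbers shown do not place it relative to compound 1 in either direction.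

Compound 3 `CC(C)(CCl)C(=O)Nc1cccc(-c2nc3ccccc3s2)c1` differs from compound 2 by 1-(chloromethyl)-1-methylethyl in place of 2-(dimethylamino)ethyl on a carbonyl carbon. Among the compounds with values here, the only measured step, a step that the two limits leave unreadable from compound 1 to compound 2, concerns a change at the same carbonyl carbon, but with both of its ends at the limit it offers no direction and no size to carry over. On the evidence shown, nothing indicates a move away from the limit for compound 3.

Compound 3 is therefore expected to give an estimated 30000 nM in this assay, within a range of 10000 nM to 100000 nM, most probably again as a limit rather than a number. The expected step is a step that the limit leaves unreadable from compound 2 to compound 3, nothing beyond the scatter.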

Compound 3, half-maximal effective concentration: > 25000 nM
Compound 3: only a limit was reported; the forecaster's own chance of this, stated with the estimate: 80%; the middle value is on the limit's open side.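

In this assay compound 3 gives > 25000 nM, which is a limit and not a number. Compound 1 and compound 2 also gave only limits, so no step among these three compounds can be read. The compounds shown leave open whether any change on the carbonyl carbon of this amide series gives a measurable value.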